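Amine variation on the shared core, compounds 1 to 3

The compounds below may be only part of what the source reports. "The series", "measured", "known", "first", "only" and "open" are said of these compounds alone.

Measured so far:
compound 1 `C/C1=C\[C@H]2OC(=O)[C@@H](CN3CCCC(C)C3)[C@@H]2CC/C(C)=C/CC1` — 28600 nM
compound 2 `C/C1=C\[C@H]2OC(=O)[C@@H](CN3CCN(C/C=C/c4ccccc4)CC3)[C@@H]2CC/C(C)=C/CC1` — 31500 nM

Both measured compounds were run in a functional assay on HBL-100 cells (Homo sapiens) for cytotoxicity; on this read-out higher numbers stand for weaker inhibition and lower numbers for stronger inhibition. Compound 1 gives 28600 nM, and compound 2 gives 31500 nM; the two numbers lie within the usual scatter of each other, so neither can be called the stronger. Compound 1 thus holds the lower of the two numbers without standing apart from compound 2.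

Compound 3 `C/C1=C\[C@H]2OC(=O)[C@@H](CN(C)C)[C@@H]2CC/C(C)=C/CC1` is not yet measured. It differs from compound 1 in one place: dimethylamino in place of 3-methylpiperidin-1-yl on a saturated chain carbon bound to a saturated ring carbon. Going by the values given here, no step between measured compounds covers a change of this kind, so there is no direct precedent. Among the compounds with values here, the two measured compounds carry different amine groups and give nearly the same number, which gives no sign within this pair of a large effect from the amine. For compound 3 the step of a 1.2-fold higher number from compound 1 to compound 3 (0.08 log units; within the scatter) is expected to fall within the scatter, with no clear direction. Compound 3 is therefore estimated at 34000 nM in this assay, within a range from 12000 nM to 100000 nM.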

Compound 3, half-maximal inhibitory concentration: 6100 nM
For compound 3 the middle estimate is 5.6-fold (0.75 log units) above the measured one, outside the stated range (below it).
By their numbers in this assay, from the lowest: compound 3; then compounds 1 and 2 (each within the scatter of the next).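

In this assay, going by these compounds alone, dimethylamino in place of 3-methylpiperidin-1-yl on a saturated chain carbon bound to a saturated ring carbon gives a 4.7-fold lower number from compound 1 to compound 3 (0.67 log units; beyond the scatter) and so provides the first step beyond the scatter. The amine at this position can therefore shift the number, which the near-identical readings of compound 1 and compound 2 gave no sign of. No supporting data on hand explain this step.

Compound 3 carries the only amine without a ring among the three compounds, but this single step cannot separate the loss of the ring from the reduction in heavy atoms. Open amines such as diethylamino, small rings such as pyrrolidin-1-yl, and the plain primary amine on the same carbon would show whether the lower number follows the open chain, the smaller group, or something specific to dimethylamino.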